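The source may hold more compounds than are shown below. What is called first, only, known or untested is meant among the compounds shown, and "the series" means these compounds.

Measured compounds in an assay on microsomes from intestine for inhibition of acyl-CoA:cholesterol acyltransferase (Oryctolagus cuniculus); on this read-out higher numbers stand for weaker inhibition and lower numbers for stronger inhibition:
compound 1, `CCCCCCCCOC(=O)NC(=O)Oc1c(C(C)C)cccc1C(C)C`, 250 nM
compound 2, `CCCCCCCCCCCCCCCCOC(=O)NC(=O)Oc1c(C(C)C)cccc1C(C)C`, 50 nM

Going by the values given here, compound 2 gives the lowest number of the two measured in this assay; the only neighbour, compound 1, gives the higher number, and the gap between them is beyond the scatter. Among the compounds with values here, the one measured step is a 5.0-fold lower number from compound 1 to compound 2 (0.70 log units; beyond the scatter), a lengthening of the saturated chain attached to the oxygen of the carbamate ester by an octyl piece.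

Compound 3, `CCCCCCCCCCCCCCCCCCOC(=O)NC(=O)Oc1c(C(C)C)cccc1C(C)C`, differs from compound 2 by ethyl in place of hydrogen on a saturated chain carbon, ten or more bonds along the chain from an oxygen next to a carbonyl group. Within the data shown here, this is a further lengthening of the same chain, but by a far shorter piece than the one that separates compound 1 from compound 2. The step from compound 1 to compound 2 was modest for a large extension; a two-carbon extension on an already long chain is expected to give a much smaller step, if any, and the direction, should one show, is expected to be toward a lower number.

Compound 3 is therefore expected to give roughly 40 nM in this assay, within a range of 20 nM to 100 nM, corresponding to a step of a 1.3-fold lower number from compound 2 to compound 3 (0.10 log units; within the scatter) that lies within the scatter.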

Compound 3, half-maximal inhibitory concentration: 1000 nM
Estimate against measurement, compound 3: 25-fold (1.40 log units) below; the measured number lies above the stated range.
By their numbers in this assay, from the lowest: compound 2; then compound 1; then compound 3.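

In this assay, lengthening the saturated chain on the carbamate oxygen does not act in one direction: the octyl extension gives a 5.0-fold lower number from compound 1 to compound 2 (0.70 log units; beyond the scatter), whereas ethyl in place of hydrogen on a saturated chain carbon, ten or more bonds along the chain from an oxygen next to a carbonyl group, gives a 20-fold higher number from compound 2 to compound 3 (1.30 log units; beyond the scatter). Even against the shorter chain the decyl extension ends on the unfavourable side, with a 4.0-fold higher number from compound 1 to compound 3 (0.60 log units; beyond the scatter), so across these three compounds the number does not follow chain length, and only compound 2 sits at the low end; a small addition at the far end of the chain can therefore outweigh the whole gain seen earlier. Nothing available bears on why the number turns upward at this chain length.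

The compounds shown leave open whether the turn is abrupt or gradual, which chains shorter than that of compound 3 but longer than that of compound 1 would settle, and whether a longer chain would raise the number further. They also leave open whether a carboxylic acid or an amine at the far end of the chain would be tolerated at this length.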